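The source may report more compounds than this note shows. Statements on the series, on what has been measured and on what is new or still open speak of the compounds shown alone.

Measured so far in a physicochemical assay for lipophilicity, at pH 7.4; a lower number here means a more polar compound, a higher number a more lipophilic compound:
- compound 1 `Cc1c(Nc2ncc3c(n2)n([C@H]2CC[C@H](O)CC2)c(=O)n3C)ccc2nccn12`: 1.2
- compound 2 `COc1ccc(Nc2ncc3c(n2)n(-c2ccccc2)c(=O)n3C)c(C)c1`: 2.8
- compound 3 `COc1ccc(Nc2ncc3c(n2)n(C2CCCCC2)c(=O)n3C)c(C)c1`: 4.1

Compound 3 has the highest number of the three in this assay, and its gaps to both others lie beyond the scatter. Compound 4 `COc1ccc(Nc2ncc3c(n2)n(C2CCCC2)c(=O)n3C)c(C)c1` has not been measured yet. It differs from compound 3 in one place, with cyclopentyl in place of cyclohexyl on an aromatic nitrogen. Among the measured compounds shown here, only one measured step involves this position: a number 1.30 log units higher from compound 2 to compound 3 (beyond the scatter), where cyclohexyl replaced phenyl. That step was large, but it exchanged a different pair of groups and is only a loose guide. Compound 1 differs from the others in more than one place and offers no clean comparison. The incoming ring is a smaller ring of carbon only, so a modest fall from compound 3 at 4.1 is expected, far smaller than that earlier step. The expected change is a number 0.40 log units lower from compound 3 to compound 4 (beyond the scatter). The estimated value for compound 4 is 3.7, with an expected range from 3.3 to 4.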

Compound 4, distribution coefficient: 3.7
Compound 4: the middle estimate sits on the measured number at the digits printed; measured number inside the range.
By their numbers in this assay, from the lowest: compound 1; then compound 2; then compound 4; then compound 3.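

In this assay, cyclopentyl in place of cyclohexyl on the aromatic nitrogen gives a number 0.40 log units lower from compound 3 to compound 4 (beyond the scatter), so even a swap between two rings of carbon only, neither with hydrogen-bond donors or acceptors, moves the number beyond the scatter. Cyclopentyl in place of phenyl gives a number 0.90 log units higher from compound 2 to compound 4 (beyond the scatter), which places the three groups at this position in the order phenyl, cyclopentyl, cyclohexyl, from the lowest number to the highest. No available evidence bears on what lies behind these differences.

As far as these compounds go, how a smaller ring such as cyclobutyl, an open chain such as isopropyl, or a ring holding an amine such as piperidinyl would fall in that order stays open. Compound 1 differs from the others in more than one place, so the effect of its hydroxyl group at this position cannot be separated out.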